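This account rests on a few compounds, and the source may have more. Where it says the series, first, only, none or still open, it means among the compounds named here.

In a functional assay on HCC827 cells (Homo sapiens) for antiproliferative activity, read by MTT assay, with a stated time of 72 h (a higher number here means a weaker inhibitor, a lower number a stronger inhibitor), compound 3 `CN(C)CCN(C)c1ccc(Nc2ncc3nc(Sc4ccccc4)n(C4CCOCC4)c3n2)cc1` gives 499 nM. Compound 1 `CN1CCC(Oc2ccc(Nc3ncc4nc([S+]([O-])c5ccccc5)n(C5CCOCC5)c4n3)cc2)CC1` gives 853 nM, within the scatter of that value. Compound 2 `CN(C)CCN(C)c1ccc(Nc2ncc3nc([S+]([O-])c4ccccc4)n(C4CCOCC4)c3n2)cc1` gives 1330 nM, and a 2.7-fold lower number from compound 2 to compound 3 (0.43 log units; beyond the scatter) marks a change at a different place in the molecule. Compound 4 `CN1CCC(Oc2ccc(Nc3ncc4nc(Sc5ccccc5)n(C5CCOCC5)c4n3)cc2)CC1` has not been measured. It differs from compound 3 at one place: (1-methylpiperidin-4-yl)oxy in place of (2-(dimethylamino)ethyl)(methyl)amino on an aromatic carbon, ((1-methylpiperidin-4-yl)oxy in place of (2-(dimethylamino)ethyl)(methyl)amino on an aromatic carbon). Within the data shown here, the only measured exchange of these two groups is a 1.6-fold higher number from compound 1 to compound 2 (0.19 log units; within the scatter), which is the same change read backwards. No step beyond the scatter is therefore expected in this assay. The estimate is a 1.5-fold lower number from compound 3 to compound 4 (0.18 log units; within the scatter), an expected small shift. Compound 4 is expected at 330 nM, with an estimated range from 150 nM to 750 nM.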

Compound 4, half-maximal inhibitory concentration: 140 nM
Compound 4: middle estimate off by 2.4-fold (0.37 log units), on the high side; measured number below the stated range.
By their numbers in this assay, from the lowest: compound 4; then compounds 3, 1 and 2 (each within the scatter of the next, the first and the last beyond it).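

With the sulfur group lacking its oxygen, (1-methylpiperidin-4-yl)oxy in place of (2-(dimethylamino)ethyl)(methyl)amino gives a step beyond the scatter (a 3.6-fold lower number from compound 3 to compound 4 (0.55 log units; beyond the scatter)), which the same exchange on the other core did not. Even so, the two readings of this exchange do not differ beyond the scatter: the same change on two cores in this assay, a 1.6-fold higher number (0.19 log units; within the scatter) from compound 1 to compound 2 and a 3.6-fold higher number (0.55 log units; beyond the scatter) from compound 4 to compound 3, 2.3-fold (0.36 log units) apart, within the scatter of two such steps

Removing the oxygen on sulfur also lowers the number with (1-methylpiperidin-4-yl)oxy in place (a 6.1-fold lower number from compound 1 to compound 4 (0.78 log units; beyond the scatter)), in the same direction as with the open chain: the same change on two cores in this assay, a 2.7-fold lower number (0.43 log units; beyond the scatter) from compound 2 to compound 3 and a 6.1-fold lower number (0.78 log units; beyond the scatter) from compound 1 to compound 4, 2.3-fold (0.36 log units) apart, within the scatter of two such steps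

The compounds shown leave open how a piperazine or a morpholine would behave at this place on the aromatic ring. They also leave open what a sulfone would do at the sulfur.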